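From an Aryl Arm to a Hydroxyethyl Chain on Myosin-2

The source may report more compounds than this note shows. Statements on the series, on what has been measured and on what is new or still open speak of the compounds shown alone.

Among the compounds with values here, compound 3 `C/C(=N\Cc1cccc(C)c1)c1c(O)c2ccccc2oc1=O` is the one compound with a number: in an assay on isolated protein for inhibition of myosin-2 (Bos taurus), read by spectrophotometry, with a stated time of 24 min (on this read-out higher numbers stand for weaker inhibition and lower numbers for stronger inhibition), compound 3 gives 4900 nM. Compound 1 `C/C(=N\Cc1ccccc1)c1c(O)c2ccccc2[nH]c1=O` reaches only a limit, >= 100000 nM. Compound 2 `CCC(C)/N=C(\C)c1c(O)c2ccccc2[nH]c1=O` likewise stops at a limit, >= 100000 nM. The step that the two limits leave unreadable from compound 1 to compound 2 therefore cannot be read, because both of its ends sit at the limit of >= 100000 nM in this assay, at which 2 of the 3 values shown sit. Within the data shown here, compound 4 `C/C(=N\CCCO)c1c(O)c2ccccc2oc1=O` differs from compound 3 by 2-hydroxyethyl in place of 3-methylphenyl on a saturated chain carbon bound to a double-bonded nitrogen, a change that no measured pair mirrors, so no measured step bears on it. Compound 3 and compound 4 also differ from compound 1 and compound 2 in their core, so those limits give no guide either. With nothing to lean on, the expected step of a 3.1-fold higher number from compound 3 to compound 4 (0.49 log units; beyond the scatter) is set towards weaker inhibition. Compound 4 is estimated at 15000 nM, between 3000 nM and 100000 nM.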

Compound 4, half-maximal inhibitory concentration: 37000 nM
Compound 4: the middle estimate sits 2.5-fold (0.39 log units) below what was measured, within the range that was stated.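

On this saturated chain carbon bound to a double-bonded nitrogen, 2-hydroxyethyl in place of 3-methylphenyl gives a 7.6-fold higher number from compound 3 to compound 4 (0.88 log units; beyond the scatter) in this assay, so the group held here matters. Even without the aromatic ring, compound 4 keeps a real number, 37000 nM, rather than a limit. Within the data shown here, nothing measured so far explains the size of this step.

Going by these compounds, the change removes a ring and adds a hydroxyl group at once, so the share of each stays open. On these data alone, how an amine or a longer chain would fare in place of 2-hydroxyethyl also stays open.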